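Removing One Chloro Group from Compound 2

The compounds below may be only part of what the source reports. "The series", "measured", "known", "first", "only" and "open" are said of these compounds alone.

Three analogues have been measured in a functional assay on A549 cells (Homo sapiens) for inhibition, read by XTT assay, with a stated time of 48 h; on this read-out lower numbers stand for stronger inhibition and higher numbers for weaker inhibition. Compound 1 `CC(=O)OC/C(=C\c1ccccc1F)C(=O)c1ccccc1` gives 68700 nM, compound 3 `COc1ccc(C(=O)/C(=C/c2c(F)c(F)c(F)c(F)c2F)CCOC(C)=O)cc1` gives 58100 nM, and compound 2 `COc1ccc(C(=O)/C(=C/c2ccc(Cl)cc2Cl)CCOC(C)=O)cc1` gives 69200 nM. Compound 2 carries the highest number of the three, but its gaps to compound 1 and to compound 3 both lie within the scatter, so no order among them can be read from these values. Compound 4 `COc1ccc(C(=O)/C(=C/c2ccccc2Cl)CCOC(C)=O)cc1` differs from compound 2 by hydrogen in place of chloro on an aromatic carbon. For the measured compounds named here, no step between measured compounds covers this change, and the three numbers point in neither direction, so a step that stays within the scatter is expected: a 1.0-fold lower number from compound 2 to compound 4 (0.00 log units; within the scatter). For compound 4 in this assay the estimated value is 69000 nM, with an expected range from 35000 nM to 140000 nM.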

Compound 4, half-maximal inhibitory concentration: > 100000 nM
Compound 4 was reported as a limit; the forecaster's own chance of this, stated with the estimate: 15%; middle value at least 1.4-fold (0.16 log units) from the limit.
By their numbers in this assay, from the lowest: compounds 3, 1 and 2 (each within the scatter of the next). At a limit, above all of these: compound 4.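

In this assay, compound 4 is reported as a limit, > 100000 nM. Going from 2,4-dichlorophenyl to 2-chlorophenyl gives an at least 1.4-fold higher number from compound 2 to compound 4 (0.15 log units; that floor lies within the scatter), so hydrogen in place of this chloro group, para to a large group, brings no lower number here. That step is only a floor, and its true size stays unknown: the limit of > 100000 nM in this assay, at which 1 of the 4 values shown sits.

Still open, from the compounds shown here alone, is whether an amine or a carboxylic acid in place of this chloro group would give a lower number than compound 2. Also open, going by these compounds, is what removing the other chloro group instead would do.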